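A few compounds are considered here, and "the series" means these few. Any claim that something is new, unique, unknown or untested is made for them only; others in the source may bear on it.

Compound 3 `COc1cc2cc(C(=O)CCc3cc[n+](CC4CCC4)cc3)sc2cc1OC` sits below compound 2 in a physicochemical assay for solubility (on this read-out lower numbers stand for lower solubility and higher numbers for higher solubility), and its gap to compound 1 lies within the usual scatter. In this assay compound 3 gives 6000 ug/mL, compound 1 `COc1cc2cc(C(=O)CCc3cc[n+](C)cc3)sc2cc1OC` gives 3000 ug/mL, and compound 2 `CCC[n+]1ccc(CCC(=O)c2cc3cc(OC)c(OC)cc3s2)cc1` gives 16000 ug/mL. Compound 4 `CCOCC[n+]1ccc(CCC(=O)c2cc3cc(OC)c(OC)cc3s2)cc1` differs from compound 3 in one place: ethoxymethyl in place of cyclobutyl on a saturated chain carbon bound to an aromatic nitrogen. Among the measured compounds shown here, three measured steps touch the same position: a 5.3-fold higher number from compound 1 to compound 2 (0.73 log units; beyond the scatter), a 2.0-fold higher number from compound 1 to compound 3 (0.30 log units; within the scatter) and a 2.7-fold lower number from compound 2 to compound 3 (0.43 log units; beyond the scatter). Each swap there moved the number only modestly, never by a large shift. An ethoxymethyl group at this position has no precedent among these compounds, so the direction is uncertain; the expected step is a 2.0-fold higher number from compound 3 to compound 4 (0.30 log units; within the scatter), a modest rise. Compound 4 is therefore estimated at 12000 ug/mL, within a range from 5000 ug/mL to 30000 ug/mL.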

Compound 4, solubility: 50000 ug/mL
Compound 4: middle estimate off by 4.2-fold (0.62 log units), on the low side; measured number above the stated range.
By their numbers in this assay, from the lowest: compounds 1 and 3 (each within the scatter of the next); then compound 2; then compound 4.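

The ethoxymethyl group, which brings an oxygen and no ring, takes this position to the top of the series in this assay, with an 8.3-fold higher number from compound 3 to compound 4 (0.92 log units; beyond the scatter), although it holds the same number of heavy atoms as cyclobutyl. Ethoxy in place of methyl on the chain also counts, with a 3.1-fold higher number from compound 2 to compound 4 (0.49 log units; beyond the scatter), and a 17-fold higher number from compound 1 to compound 4 (1.22 log units; beyond the scatter) is the first large step seen here. Nothing measured here explains the rise.

From the compounds shown here alone, whether the oxygen or the open chain carries the rise stays open. A butyl group in place of ethoxymethyl would separate the two, and an amine at the same place would show whether another heteroatom behaves alike.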